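This account rests on a few compounds, and the source may have more. Where it says the series, first, only, none or still open, it means among the compounds named here.

Three compounds of one shared core have been measured in a functional assay on K562 cells (Homo sapiens) for cytotoxicity, read by MTT assay, with a stated time of 72 h; a higher number here means a weaker inhibitor, a lower number a stronger inhibitor:

Compound 1 `C=C1C(=O)[C@@]23C(=O)OC[C@]4(C(=O)CCC(C)(C)[C@H]4C=O)[C@@H]2CC[C@@H]1[C@H]3O` gives 2180 nM.
Compound 2 `C=C1C(=O)[C@@]23C(=O)OC[C@]4(C(=O)CCC(C)(C)[C@H]4C=O)[C@@H]2CC[C@@H]1[C@H]3OC(=O)c1ccccc1` gives 1480 nM.
Compound 3 `C=C1C(=O)[C@@]23C(=O)OC[C@]4(C(=O)CCC(C)(C)[C@H]4C=O)[C@@H]2CC[C@@H]1[C@H]3OC(=O)c1ccc([N+](=O)[O-])cc1` gives 1330 nM.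

Compound 2 stands second highest of the three numbers in this assay. Its nearest neighbour is compound 3, with a 1.1-fold lower number from compound 2 to compound 3 (0.05 log units; within the scatter), and the step of a 1.5-fold lower number from compound 1 to compound 2 (0.17 log units; within the scatter) is also within the scatter, so the three values cannot be told apart.

Compound 4 `C=C1C(=O)[C@@]23C(=O)OC[C@]4(C(=O)CCC(C)(C)[C@H]4C=O)[C@@H]2CC[C@@H]1[C@H]3OC(=O)c1ccccc1F` differs from compound 2 by fluoro in place of hydrogen on an aromatic carbon. Within the data shown here, the one measured step that bears on it is the change on the same aromatic ring, a 1.1-fold lower number from compound 2 to compound 3 (0.05 log units; within the scatter), which stayed within the scatter. The steps of a 1.5-fold lower number from compound 1 to compound 2 (0.17 log units; within the scatter) and a 1.6-fold lower number from compound 1 to compound 3 (0.21 log units; within the scatter) show that the whole ester, with or without a ring substituent, moved the number by less than the scatter. No step beyond the scatter is therefore expected for a 1.1-fold lower number from compound 2 to compound 4 (0.02 log units; within the scatter). Compound 4 is estimated at 1400 nM, with a range from 700 nM to 2800 nM in this assay.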

Compound 4, half-maximal inhibitory concentration: 2860 nM
Compound 4: the middle estimate sits 2.0-fold (0.31 log units) below what was measured; the measured number lies above the stated range.
By their numbers in this assay, from the lowest: compounds 3, 2, 1 and 4 (each within the scatter of the next, the first and the last beyond it).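

In this assay, fluoro on an aromatic carbon ortho to a large group gives a 1.9-fold higher number from compound 2 to compound 4 (0.29 log units; within the scatter), and the whole (2-fluorophenyl)carbonyl ester gives a 1.3-fold higher number from compound 1 to compound 4 (0.12 log units; within the scatter), so neither step on its own can be told from the scatter. The earlier compounds shown here offered no step beyond the scatter, but a 2.2-fold higher number from compound 3 to compound 4 (0.33 log units; beyond the scatter) is one, though modest, and it shows that 2-fluorophenyl and 4-nitrophenyl on the carbonyl carbon can be told apart. No evidence is given that accounts for this separation.

The compounds shown leave open whether the separation belongs to the fluoro, to the nitro, or to where each sits on the ring. They also leave open what a methoxy group or an amine on the same ring, or an acetyl in place of the benzoyl, would do in this assay.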